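A Methoxy-for-Methyl Step Tested on a Second Core

A few compounds are considered here, and "the series" means these few. Any claim that something is new, unique, unknown or untested is made for them only; others in the source may bear on it.

Compound 1 `Cc1ccccc1OCC(O)CNCC(=O)Nc1ccc(C2=NNC(=O)CC2)cc1` and compound 3 `Cc1ccccc1OCC(O)CNCCC(=O)Nc1ccc(C2=NNC(=O)CC2)cc1` share a large part of their structure, but the difference between their two cores is not broken down here. In a functional assay on the whole organism with Rattus norvegicus as the target (on this read-out lower numbers stand for an effect already at smaller amounts and higher numbers for an effect only at larger amounts of compound), compound 1 gives 2 umol/kg, while compound 3 gives 6 umol/kg in the same assay; the gap between these two numbers lies beyond the scatter.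

Compound 2 `COc1ccccc1OCC(O)CNCC(=O)Nc1ccc(C2=NNC(=O)CC2)cc1` differs from compound 1 by methoxy in place of methyl on an aromatic carbon. In this assay compound 2 gives 4.6 umol/kg, which amounts to a 2.3-fold higher number from compound 1 to compound 2 (0.36 log units; beyond the scatter). The numbers for compound 2 and compound 3 lie within the scatter of each other, so nothing is said about their order.

Compound 4 `COc1ccccc1OCC(O)CNCCC(=O)Nc1ccc(C2=NNC(=O)CC2)cc1` has not yet been measured. It differs from compound 3 by methoxy in place of methyl on an aromatic carbon, and the place of the change is described in the same terms as for the step from compound 1 to compound 2, so it is taken as the same change carried onto the core of compound 3. This change has been measured only once among the compounds shown, so the range given for compound 4 is kept wide. If the change behaves as it did in a 2.3-fold higher number from compound 1 to compound 2 (0.36 log units; beyond the scatter), a step of about a 2.3-fold higher number from compound 3 to compound 4 (0.37 log units; beyond the scatter) is expected, starting from the number of compound 3 in this assay, 6 umol/kg. For compound 4 in this assay the estimate is 14 umol/kg, with an expected range from 7 umol/kg to 28 umol/kg.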

Compound 4, dose for half-maximal effect: 4.3 umol/kg
For compound 4 the middle estimate is 3.3-fold (0.51 log units) above the measured one, outside the stated range (below it).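

On the core of compound 3, methoxy in place of methyl on the aromatic carbon does not repeat what it did on the core of compound 1: in this assay the new pair shows a 1.4-fold lower number from compound 3 to compound 4 (0.14 log units; within the scatter), so no difference between the two compounds can be read from it. The two steps differ from each other by more than repeated measurements would explain, so in this series the effect of this change depends on the core that carries it: the same change on two cores in this assay, a 2.3-fold higher number (0.36 log units; beyond the scatter) from compound 1 to compound 2 and a 1.4-fold lower number (0.14 log units; within the scatter) from compound 3 to compound 4, 3.2-fold (0.51 log units) apart, beyond the scatter of two such steps

This shows that the step seen on one core could not be carried over as a number to the other, but it does not show why the two cores part ways, nor does it give a rule for any further core, since the comparison rests on a single pair from each.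

The compounds shown leave open how ethoxy or chloro on the same aromatic carbon would behave on either core, and whether such groups would also give steps that differ between the cores. They also leave open which of the two steps, if either, the methoxy-for-methyl change would follow on a core with a longer chain.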